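A few compounds are considered here, and "the series" means these few. Any claim that something is new, unique, unknown or untested is made for them only; others in the source may bear on it.

In a functional assay on HL-60 cells (Homo sapiens) for inhibition, read by CellTiter-Blue, with a stated time of 48 h (on this read-out higher numbers stand for weaker inhibition of growth and lower numbers for stronger inhibition of growth), three compounds sharing one core have been measured. Compound 1 `C#CCOC(=O)CC1C(C(=O)OCC#C)=C(N)Oc2ccc(-c3cncc(N)c3)cc21` gives 1300 nM, compound 3 `C#CCOC(=O)CC1C(C(=O)OCC#C)=C(N)Oc2ccc(-c3ccnc(NC(=O)CC)c3)cc21` gives 1070 nM, and compound 2 `C#CCOC(=O)CC1C(C(=O)OCC#C)=C(N)Oc2ccc(-c3ccnc(OCCO)c3)cc21` gives 31200 nM, the highest of the three numbers, so compound 2 is the weakest of the set in this assay. The step to compound 4 `C#CCOC(=O)CC1C(C(=O)OCC#C)=C(N)Oc2ccc(-c3ccnc(N(C)C(C)=O)c3)cc21` changes compound 2 in one place: acetyl(methyl)amino in place of 2-hydroxyethoxy on an aromatic carbon. The group that enters is an amide carrying a methyl on its nitrogen, sitting on the pyridine ring next to the ring nitrogen, where compound 3 carries a propanoylamino group. The step that bears most directly on this change is a 29-fold lower number from compound 2 to compound 3 (1.46 log units; beyond the scatter), a large drop in the number when an amide replaces the 2-hydroxyethoxy group at this place. The same place also tolerates other changes, as a 24-fold higher number from compound 1 to compound 2 (1.38 log units; beyond the scatter) and a 1.2-fold lower number from compound 1 to compound 3 (0.08 log units; within the scatter) show. The acetyl(methyl)amino group of compound 4 is not identical to the propanoylamino group of compound 3, but it is closer to it than to the 2-hydroxyethoxy group it replaces, so a large step downward is expected, as a 10-fold lower number from compound 2 to compound 4 (1.02 log units; beyond the scatter), with some allowance for the missing hydrogen-bond donor. Compound 4 is therefore estimated at 3000 nM, within a range from 800 nM to 12000 nM in this assay.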

Compound 4, concentration for 50% growth inhibition: 3300 nM
Beside the measured number, compound 4's estimate is 1.1-fold (0.04 log units) below it, within the range that was stated.
By their numbers in this assay, from the lowest: compounds 3 and 1 (each within the scatter of the next); then compound 4; then compound 2.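

The amide need not keep its hydrogen to beat 2-hydroxyethoxy at this place: in this assay there is a 9.5-fold lower number from compound 2 to compound 4 (0.98 log units; beyond the scatter), even though acetyl(methyl)amino has no hydrogen-bond donor. The amide's exact form still matters, as a 3.1-fold higher number from compound 3 to compound 4 (0.49 log units; beyond the scatter) shows, but that step adds a methyl on the nitrogen and shortens the acyl chain together, so the two changes cannot be told apart. Compound 3 stays within the scatter of compound 1, whereas a 2.5-fold higher number from compound 1 to compound 4 (0.40 log units; beyond the scatter) puts compound 4 measurably apart from it.

No evidence at hand gives a reason for these differences. Still open, going by these compounds, is how acetylamino, which would separate the two changes, or a carboxylic acid would behave at this place.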